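Working notes on the step to compound 3

The source may hold more compounds than are shown below. What is called first, only, known or untested is meant among the compounds shown, and "the series" means these compounds.

compound 1 (`OC1CN(c2nccnc2OC2CN(c3ccc4ccccc4n3)C2)C1`): 41000 nM
compound 2 (`Cc1ccc(-c2nccnc2OC2CN(c3ccc4ccccc4n3)C2)cc1`): < 1000 nM (a limit)

In a physicochemical assay for solubility, in phosphate buffer, at pH 7.4 (on this read-out lower numbers stand for lower solubility and higher numbers for higher solubility), compound 2 stands only at a limit (< 1000 nM), not at a number. Compound 3 (`c1ccc2nc(N3CC(Oc4nccnc4-c4ccc5scnc5c4)C3)ccc2c1`) carries 1,3-benzothiazol-5-yl in place of 4-methylphenyl on an aromatic carbon. For the measured compounds named here, the one measured step (an at least 41-fold lower number from compound 1 to compound 2 (1.61 log units; beyond the scatter)) is large and puts 4-methylphenyl in place of 3-hydroxyazetidin-1-yl. Compound 3 keeps an aromatic group at that place, so no step beyond the scatter is expected in this assay, in either direction. The expected step is small (a step that the limit leaves unreadable from compound 2 to compound 3). For compound 3 the estimated value is 800 nM (range 250 nM to 3000 nM).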

Compound 3, solubility: < 1000 nM
Compound 3 gave a limit, no number; the forecaster's own chance of this, stated with the estimate: 65%; the middle value does not contradict the limit.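

In this assay, a second aromatic group at this position, 1,3-benzothiazol-5-yl, in place of 3-hydroxyazetidin-1-yl gives an at least 41-fold lower number from compound 1 to compound 3 (1.61 log units; beyond the scatter). Compound 3 also stands at a limit and not at a number, even with the hydrogen-bond acceptors that 1,3-benzothiazol-5-yl brings in. The step from 4-methylphenyl to 1,3-benzothiazol-5-yl cannot be read, because both values are limits: the limit of < 1000 nM in this assay, at which 2 of the 3 values shown sit.

Going by these compounds, the order of compound 2 and compound 3 stays open. So does whether an aromatic group carrying an amine or a carboxylic acid at this position would give a readable number.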